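Methoxy in Place of Methyl on the Aromatic Carbon

The source may hold more compounds than are shown below. What is called first, only, known or untested is meant among the compounds shown, and "the series" means these compounds.

Among the compounds with values here, compound 2 `CC[C@@H]1/C=C(\C)C[C@H](C)C[C@H](OC)[C@H]2O[C@@](O)(C(=O)C(=O)N3CCCC[C@H]3C(=O)O[C@H](/C(C)=C/[C@@H]3CC[C@@H](O)[C@H](Oc4ccc(C)cc4)C3)[C@H](C)[C@@H](O)CC1=O)[C@H](C)C[C@@H]2OC` gives 2.6 nM in a functional assay on cells for inhibition, with Murine T-cell line (Mus musculus) as the target (on this read-out lower numbers stand for stronger inhibition and higher numbers for weaker inhibition), the highest of the two numbers so far; its nearest neighbour, compound 1 `CC[C@@H]1/C=C(\C)C[C@H](C)C[C@H](OC)[C@H]2O[C@@](O)(C(=O)C(=O)N3CCCC[C@H]3C(=O)O[C@H](/C(C)=C/[C@@H]3CC[C@@H](O)[C@H](Oc4ccc(O)cc4)C3)[C@H](C)[C@@H](O)CC1=O)[C@H](C)C[C@@H]2OC`, gives 0.9 nM. Within the data shown here, the single step recorded, a 2.9-fold higher number from compound 1 to compound 2 (0.46 log units; beyond the scatter), altered the same aromatic carbon that now changes again. Compound 3 `CC[C@@H]1/C=C(\C)C[C@H](C)C[C@H](OC)[C@H]2O[C@@](O)(C(=O)C(=O)N3CCCC[C@H]3C(=O)O[C@H](/C(C)=C/[C@@H]3CC[C@@H](O)[C@H](Oc4ccc(OC)cc4)C3)[C@H](C)[C@@H](O)CC1=O)[C@H](C)C[C@@H]2OC` differs from compound 2 by methoxy in place of methyl on an aromatic carbon. Because a 2.9-fold higher number from compound 1 to compound 2 (0.46 log units; beyond the scatter) was only modest, a similar or smaller step toward a lower number, or none beyond the scatter, is expected for compound 3. Compound 3 is therefore estimated at 1.8 nM, between 0.7 nM and 4.5 nM, which amounts to a 1.4-fold lower number from compound 2 to compound 3 (0.16 log units; within the scatter).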

Compound 3, half-maximal inhibitory concentration: 0.9 nM
Estimate against measurement, compound 3: 2.0-fold (0.30 log units) above, within the range that was stated.
By their numbers in this assay, from the lowest: compounds 1 and 3 (each within the scatter of the next); then compound 2.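

Replacing methyl with methoxy at this aromatic carbon gives a 2.9-fold lower number from compound 2 to compound 3 (0.46 log units; beyond the scatter) in this assay and so reverses the earlier loss, while methylating the oxygen of the hydroxy group gives no change at the digits printed from compound 1 to compound 3 (within the scatter) in the same assay. Hydroxy and methoxy thus read alike at this position, and among these three compounds only the methyl of compound 2 stands apart. No measurement shown here accounts for this result. As far as these compounds go, whether an oxygen attached to this carbon is what matters remains open. An amine, a carboxylic acid or an ethoxy group here could test that.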